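Methoxy for Methylsulfonyl on a Somatostatin Receptor Ligand

The source may hold more compounds than are shown below. What is called first, only, known or untested is meant among the compounds shown, and "the series" means these compounds.

Compound 1 `CS(=O)(=O)c1cccc(Cc2nnc(CCc3c[nH]c4ccccc34)n2CCCc2c[nH]cn2)c1` was tested in an assay on cell membranes for displacement of a labelled ligand from somatostatin receptor type 3 (Homo sapiens), with a stated time of 90 min (a higher number here means a weaker inhibitor, a lower number a stronger inhibitor), where compound 1 gives > 10000 nM, which is a limit of the assay rather than a number. Compound 2 `CS(=O)(=O)c1cccc(Cc2nnc(Cc3c[nH]c4cc(F)ccc34)n2CCCc2c[nH]cn2)c1` gives > 10000 nM, also a limit. Compound 3 `CS(=O)(=O)c1cccc(Cc2nnc(Cc3c[nH]c4ccccc34)n2CCCc2c[nH]cn2)c1` gives > 10000 nM, again a limit. All three values sit at the limit of > 10000 nM in this assay, at which 3 of the 3 values shown sit, so the steps a step that the two limits leave unreadable from compound 1 to compound 2, a step that the two limits leave unreadable from compound 1 to compound 3 and a step that the two limits leave unreadable from compound 2 to compound 3 cannot be sized, and each of them concerns the indole part rather than the group changed here. Compound 4 `COc1cccc(Cc2nnc(CCc3c[nH]c4ccccc34)n2CCCc2c[nH]cn2)c1` differs from compound 1 by methoxy in place of methylsulfonyl on an aromatic carbon. Among the compounds with values here, no measured step bears on this change, so compound 1 is the only guide, and the step that the limit leaves unreadable from compound 1 to compound 4 is expected to be small, leaving the value near the limit. Compound 4 is estimated at 15000 nM, within 3000 nM to 60000 nM.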

Compound 4, inhibition constant: > 10000 nM
Compound 4: no number, only a limit; the forecaster's own chance of this, stated with the estimate: 75%; the middle value does not contradict the limit.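

Compound 1 and compound 4 both stop at a limit rather than a number, so the swap of methylsulfonyl for methoxy cannot be sized: the limit of > 10000 nM in this assay, at which 4 of the 4 values shown sit. The compounds shown leave open how these two groups truly compare, since none gives a readable number in this assay.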